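Swapping the Aryl Substituents on a Kallikrein-7 Inhibitor

A few compounds are considered here, and "the series" means these few. Any claim that something is new, unique, unknown or untested is made for them only; others in the source may bear on it.

For the measured compounds named here, in an assay on isolated protein for inhibition of kallikrein-7 (Homo sapiens), read by fluorescence, with stated times of 10 min and 30 min (on this read-out higher numbers stand for weaker inhibition and lower numbers for stronger inhibition), compound 2 `CN(C)/N=C1/CN(CC(=O)Nc2cccc(-c3cnn(C)c3)c2)C(=O)C(Cc2c(F)cccc2C(F)(F)F)CN1` gives 2700 nM, the higher of the two numbers measured so far, though the gap to its only neighbour lies within the scatter. That neighbour, compound 1 `Cc1cccc(F)c1CC1CN/C(=N\N(C)C)CN(CC(=O)Nc2cccc(-c3cnn(C)c3)c2)C1=O`, gives 2300 nM, and the step of a 1.2-fold higher number from compound 1 to compound 2 (0.07 log units; within the scatter) stays within the scatter. Compound 3 `CN(C)/N=C1/CN(CC(=O)Nc2cccc(-c3cnn(C)c3)c2)C(=O)C(Cc2ccccc2Cl)CN1` arises from compound 2 through (2-chlorophenyl in place of 2-fluoro-6-(trifluoromethyl)phenyl on a saturated chain carbon bound to a saturated ring carbon). Going by the values given here, the single measured step concerns substituents on the same ring and showed nothing beyond the scatter, so for compound 3 only a small step in this assay is expected: a 1.1-fold higher number from compound 2 to compound 3 (0.05 log units; within the scatter). Compound 3 is therefore estimated at 3000 nM, with a range from 1200 nM to 7500 nM.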

Compound 3, half-maximal inhibitory concentration: 2500 nM
For compound 3 the middle estimate is 1.2-fold (0.08 log units) above the measured one; low and high end bracket the measured number.
By their numbers in this assay, from the lowest: compounds 1, 3 and 2 (each within the scatter of the next).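

Replacing the whole 2-fluoro-6-(trifluoromethyl)phenyl group with 2-chlorophenyl, a change from 11 heavy atoms to 7, gives a 1.1-fold lower number from compound 2 to compound 3 (0.03 log units; within the scatter) and the replacement of 2-fluoro-6-methylphenyl gives a 1.1-fold higher number from compound 1 to compound 3 (0.04 log units; within the scatter) as well. At this place on a saturated chain carbon bound to a saturated ring carbon, all three aryl groups therefore read alike in this assay despite the change in substitution and size. No evidence is available that bears on this result. Still open, on these data alone, is whether an amine or a carboxylic acid on the phenyl ring, or a longer chain at this place, would move the number beyond the scatter.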